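Naphthalen-1-yl in place of pyridin-4-yl on a ring nitrogen

The compounds below may be only part of what the source reports. "The series", "measured", "known", "first", "only" and "open" are said of these compounds alone.

Compound 1 `Nc1scc(CN2CCN(c3ccc(Cl)cc3Cl)CC2)c1C(=O)c1ccc(Cl)cc1`: 2%
Compound 2 `Nc1scc(CN2CCN(c3ccncc3)CC2)c1C(=O)c1ccc(Cl)cc1`: -4%

Of the compounds shown here, two sharing one core have been tested in a functional assay on CHO cells with adenosine receptor A1 (Homo sapiens) as the target, read by cAMP accumulation and immunoassay, with a stated time of 6 min, tested at 0.01 uM; a lower number here means a stronger effect, a higher number a weaker effect of the compound at the concentration tested. Compound 1 `Nc1scc(CN2CCN(c3ccc(Cl)cc3Cl)CC2)c1C(=O)c1ccc(Cl)cc1` gives 2%. Compound 2 `Nc1scc(CN2CCN(c3ccncc3)CC2)c1C(=O)c1ccc(Cl)cc1` gives -4%. Going by the values given here, the one measured step, a number 6 percentage points lower from compound 1 to compound 2 (within the scatter), shows that exchanging the group on the amine nitrogen in the ring left the read-out essentially unchanged. Compound 2 thus stands at the lower of two numbers, but its distance to compound 1 is within the scatter, so no order between them can be claimed.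

Compound 3 `Nc1scc(CN2CCN(c3cccc4ccccc34)CC2)c1C(=O)c1ccc(Cl)cc1` is not yet measured. Its difference from compound 2 is naphthalen-1-yl in place of pyridin-4-yl on an amine nitrogen in a ring. Among the compounds with values here, the only step that bears on this change is the one from compound 1 to compound 2, which was within the scatter, and both measured compounds sit close to zero. On that basis the step of a number 4 percentage points higher from compound 2 to compound 3 (within the scatter) is expected to stay within the scatter in this assay. Compound 3 is therefore estimated to give 0%, with a range from -15% to 15%.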

Compound 3, a percentage reported as activity, at one concentration (the size of the read-out at that concentration, not a potency): 8.7%
For compound 3 the middle estimate is 8.7 percentage points below the measured one, within the range that was stated.
By their numbers in this assay, from the lowest: compounds 2, 1 and 3 (each within the scatter of the next, the first and the last beyond it).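

In this assay, the exchange on the amine nitrogen in a ring now produces a step that can be read, a number 12.7 percentage points higher from compound 2 to compound 3 (beyond the scatter), so the naphthalen-1-yl group gives a weaker effect at the concentration tested than the pyridin-4-yl group, which the earlier pair, with its step inside the scatter, could not show of any group at this place. The same naphthalen-1-yl group set against 2,4-dichlorophenyl gives a number 6.7 percentage points higher from compound 1 to compound 3 (within the scatter), so compound 1 stays within the scatter of both compound 2 and compound 3, and the three compounds do not divide cleanly into those with a carbon-only aromatic group and the one with a ring nitrogen. Nothing measured here accounts for the step between compound 2 and compound 3.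

As far as these compounds go, what remains open is whether the effect at this place depends on an aromatic group sitting directly on the nitrogen at all, which a benzyl group, an acetyl group or a simple methyl group there would address. Since every value comes from one concentration, the compounds shown also leave open whether this modest step would carry over into a difference in potency.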